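The source may hold more compounds than are shown below. What is called first, only, known or untested is meant among the compounds shown, and "the series" means these compounds.

Working notes on the series. Compound 3 `O=C(COc1ccc2c(=O)ccoc2c1)Nc1cccc(NC(=O)c2ccc(OC(F)(F)F)cc2)c1` gives 869 nM in an assay on isolated protein for inhibition of Rho-associated protein kinase 1 (Homo sapiens), read by scintillation counting, radiometric assay and 33P incorporation, with a stated time of 40 min, in the presence of a further agent that is not named here (on this read-out lower numbers stand for stronger inhibition and higher numbers for weaker inhibition), the highest of the three numbers. Compound 1 `CCCc1ccc(C(=O)Nc2cccc(NC(=O)COc3ccc4c(=O)ccoc4c3)c2)cc1` gives 143 nM and compound 2 `CC(C)(C)c1ccc(C(=O)Nc2cccc(NC(=O)COc3ccc4c(=O)ccoc4c3)c2)cc1` gives 165 nM in this assay; the step of a 1.2-fold higher number from compound 1 to compound 2 (0.06 log units; within the scatter) lies within the scatter, whereas a 6.1-fold higher number from compound 1 to compound 3 (0.78 log units; beyond the scatter) and a 5.3-fold higher number from compound 2 to compound 3 (0.72 log units; beyond the scatter) lie beyond it. Compound 4 `O=C(COc1ccc2c(=O)ccoc2c1)Nc1cccc(NC(=O)c2ccc([N+](=O)[O-])cc2)c1` differs from compound 3 by nitro in place of trifluoromethoxy on an aromatic carbon. For the measured compounds named here, no measured step touches a nitro group; the two steps that bear on the site only show that leaving the alkyl for trifluoromethoxy raised the number, and they do not tell how nitro compares with trifluoromethoxy. A step of about a 1.2-fold lower number from compound 3 to compound 4 (0.09 log units; within the scatter) in this assay is therefore expected, with low confidence in its direction. Compound 4 is estimated at 700 nM, within 200 nM to 2500 nM.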

Compound 4, half-maximal inhibitory concentration: 67 nM
The estimate for compound 4 lay 10-fold (1.02 log units) above the measured number; measured number outside the range, below it.
By their numbers in this assay, from the lowest: compound 4; then compounds 1 and 2 (each within the scatter of the next); then compound 3.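

At the aromatic carbon para to a large group, nitro gives a lower number in this series than either alkyl group (a 2.5-fold lower number from compound 2 to compound 4 (0.39 log units; beyond the scatter); a 2.1-fold lower number from compound 1 to compound 4 (0.33 log units; beyond the scatter)), both steps beyond the scatter in this assay. The large step (a 13-fold lower number from compound 3 to compound 4 (1.11 log units; beyond the scatter)) shows that the rise seen on leaving the alkyl groups for trifluoromethoxy does not hold for nitro, so the site separates these two groups sharply. No evidence at hand gives a cause for this order.

Going by these compounds, whether a nitrile or an amine at this carbon would keep a number as low as that of compound 4 remains open.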